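The compounds below may be only part of what the source reports. "The series", "measured", "known", "first", "only" and "open" are said of these compounds alone.

Compound 1 `CCCCCCC(CCO)n1cnc2c(Cl)ncnc21` gives 11900 nM
Compound 2 `CCCCCCC(CCO)n1cnc2c(OC)ncnc21` gives > 50000 nM (a limit of the assay, not a number)

Within the data shown here, in a functional assay on HCT-116 cells (Homo sapiens) for antiproliferative activity, read by MTT assay, with a stated time of 48 h (on this read-out higher numbers stand for weaker inhibition and lower numbers for stronger inhibition), compound 1 gives 11900 nM, the only actual number so far. Compound 3 `OCCC(CO)n1cnc2c(Cl)ncnc21` keeps the chloro group but has hydroxy in place of pentyl on a saturated chain carbon, two bonds along the chain from an aromatic nitrogen. Among the measured compounds shown here, the one measured step, an at least 4.2-fold higher number from compound 1 to compound 2 (0.62 log units; beyond the scatter), swaps chloro for methoxy, and no measured step touches the chain. It therefore offers only a loose guide, and a higher number is expected in this assay. The expected change is a 3.4-fold higher number from compound 1 to compound 3 (0.53 log units; beyond the scatter). For compound 3 the estimate is 40000 nM, with an expected range from 15000 nM to 110000 nM.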

Compound 3, half-maximal inhibitory concentration: > 50000 nM
Compound 3 gave a limit, no number (the forecaster's own chance of this, stated with the estimate: 55%); at least 1.2-fold (0.09 log units) between middle value and limit.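

With the chloro group kept, hydroxy in place of pentyl on a saturated chain carbon gives an at least 4.2-fold higher number from compound 1 to compound 3 (0.62 log units; beyond the scatter) in this assay. The chain can therefore weaken the read-out as well, whereas the earlier step showed this only for a change at the chloro group. The true size of the step cannot be read, because compound 3 gives only a limit: the limit of > 50000 nM in this assay, at which 2 of the 3 values shown sit.

Going by these compounds, whether a propyl group or a longer chain such as octyl would match compound 1 stays open. So does the effect of an amine in place of the chloro group.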